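The compounds below may be only part of what the source reports. "The series", "measured", "known", "first", "only" and "open" are said of these compounds alone.

Measured in an ADME assay on HeLa cells (Homo sapiens) for cytotoxicity; a lower number here means that less compound is tolerated, a higher number that more compound is tolerated:
- compound 1 `CCN(CC)CN1C(=O)/C(=N/NC(=S)Nc2ccc(Cl)cc2)c2ccccc21`: 9800 nM
- compound 2 `CCN(CC)CN1C(=O)/C(=N/NC(N)=S)c2cc(Cl)ccc21`: > 100000 nM
- compound 3 `CCN(CC)CN1C(=O)/C(=N/NC(=S)Nc2ccccc2)c2ccccc21`: 10800 nM

Compound 2 is reported only as a limit of the assay, > 100000 nM, and not as a number. Going by these compounds, the two other compounds have measured values, so its exact distance from them is unknown.

The next compound, compound 4 `CCN(CC)CN1C(=O)/C(=N/NC(=S)Nc2ccc(OC)cc2)c2cc(Cl)ccc21`, changes compound 2 in one place: 4-methoxyphenyl in place of hydrogen on an amide-type nitrogen. This puts 4-methoxyphenyl in place of hydrogen on an amide-type nitrogen.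

Within the data shown here, no measured step covers this change directly. Among the measured compounds shown here, the only step available is a 1.1-fold higher number from compound 1 to compound 3 (0.04 log units; within the scatter), which lies within the scatter and concerns a hydrogen in place of chloro on an aromatic carbon. It suggests that this one swap on the aromatic ring made no visible difference here. Compound 1 and compound 3 both carry an aromatic ring on that nitrogen, but they lack the chloro on the core of compound 2. The expectation therefore rests, with some caution, on compound 1 at 9800 nM and compound 3 at 10800 nM.

A clear move towards lower numbers in this assay is expected, and the estimated step is an at least 10-fold lower number from compound 2 to compound 4 (1.00 log units; beyond the scatter). For compound 4 the estimated value is 10000 nM, with an expected range from 3000 nM to 35000 nM.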

Compound 4, half-maximal cytotoxic concentration: 13200 nM
Compound 4: the middle estimate sits 1.3-fold (0.12 log units) below what was measured, within the range that was stated.
By their numbers in this assay, from the lowest: compounds 1, 3 and 4 (each within the scatter of the next). At a limit, above all of these: compound 2.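

In this assay, 4-methoxyphenyl in place of hydrogen on the amide-type nitrogen, whose other neighbour is the thiocarbonyl carbon, gives a change beyond the scatter: an at least 7.5-fold lower number from compound 2 to compound 4 (0.87 log units; beyond the scatter). Among these compounds, the earlier step at hand, a 1.1-fold higher number from compound 1 to compound 3 (0.04 log units; within the scatter), concerned a chloro on an aromatic carbon and lay within the scatter, so this result is the first to show that a swap of one group can visibly move the number, here at this nitrogen. Compound 2 stands at a limit of the assay, > 100000 nM, so the step can be read only as a lower bound and its full size stays unknown: the limit of > 100000 nM in this assay, at which 1 of the 4 values shown sits.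

The compounds shown leave open whether an aromatic ring is needed on this nitrogen at all, or whether a methyl group or a longer chain such as butyl would bring the number down as far on the same core. Among the compounds shown here, they also leave open what the methoxy group itself contributes, since no step isolates it from the rest of the 4-methoxyphenyl group.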